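Removing a chloro: one change, one precedent, one expectation

This account rests on a few compounds, and the source may have more. Where it says the series, first, only, none or still open, it means among the compounds named here.

Of the compounds shown here, three have been measured in a functional assay on the whole organism for antagonist activity, with Mus musculus as the target; on this read-out lower numbers stand for an effect already at smaller amounts and higher numbers for an effect only at larger amounts of compound. Compound 3 `Cc1nnc(CNC(=O)CN)n1-c1ccc(Cl)cc1C(=O)c1ccccc1Cl` gives 0.58 mg/kg, compound 1 `Cc1nnc(CNC(=O)CN)n1-c1ccc(Cl)cc1C(=O)c1ccccc1` gives 3.02 mg/kg, and compound 2 `CN(C(=O)CNC(=O)CN)c1ccc(Cl)cc1C(=O)c1ccccc1Cl` gives 3.2 mg/kg. Compound 1 arises from compound 3 by hydrogen in place of chloro on an aromatic carbon, and that step reads a 5.2-fold higher number from compound 3 to compound 1 (0.72 log units; beyond the scatter). How the cores of compound 2 and compound 3 differ is not broken down here; their values in this assay lie far apart.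

Compound 4 `CN(C(=O)CNC(=O)CN)c1ccc(Cl)cc1C(=O)c1ccccc1` arises from compound 2 by the same change, (hydrogen in place of chloro on an aromatic carbon). Because the earlier step of a 5.2-fold higher number from compound 3 to compound 1 (0.72 log units; beyond the scatter) raised the number clearly, compound 4 is expected to show a comparable rise, a 4.1-fold higher number from compound 2 to compound 4 (0.61 log units; beyond the scatter), resting on that single precedent alone. In this assay compound 4 is therefore estimated at 13 mg/kg, with a likely range from 5 mg/kg to 35 mg/kg.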

Compound 4, dose for half-maximal effect: 10.9 mg/kg
Compound 4: the middle estimate sits 1.2-fold (0.08 log units) above what was measured; the range from low to high includes it.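

In this assay, hydrogen in place of chloro again gives a higher number on the second core (a 3.4-fold higher number from compound 2 to compound 4 (0.53 log units; beyond the scatter)). Set beside the earlier step, the change goes the same way on both cores, and the two sizes cannot be told apart: the same change on two cores in this assay, a 5.2-fold higher number (0.72 log units; beyond the scatter) from compound 3 to compound 1 and a 3.4-fold higher number (0.53 log units; beyond the scatter) from compound 2 to compound 4, 1.5-fold (0.18 log units) apart, within the scatter of two such steps. This shows that the change carried over between these two cores, but two cores are a narrow base that shows neither why the number rises nor whether the step would hold on any other core in the series.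

Going by these compounds, whether fluoro, bromo or methyl in that place would behave like chloro or like hydrogen stays open. So does the size of the step on a core carrying a longer chain in place of the terminal amine.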